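Acid chain variation on the shared aryl-thio core

The source may hold more compounds than are shown below. What is called first, only, known or untested is meant among the compounds shown, and "the series" means these compounds.

Measured so far:
compound 1, `CN(c1cnccc1SCCCC(=O)O)c1ccc(C#N)c2ccccc12`, gives 2580 nM in an assay on HEK293 cells for inhibition of solute carrier family 22 member 12 (Homo sapiens), read by scintillation counting, with stated times of 30 min and 15 min; a higher number here means a weaker inhibitor, a lower number a stronger inhibitor.
compound 2, `N#Cc1ccc(Oc2cnccc2SCCCCCC(=O)O)c2ccccc12`, gives 4740 nM in this assay.
compound 3, `CN(c1cnccc1SCCCCCC(=O)O)c1ccc(C#N)c2ccccc12`, gives 3760 nM in this assay.

Compound 2 has the highest of the three numbers, though its gaps to compound 3 and to compound 1 both sit within the scatter. Compound 4, `CC(C)(Sc1ccncc1Oc1ccc(C#N)c2ccccc12)C(=O)O`, is unmeasured. Its change from compound 2 is 1-carboxy-1-methylethyl in place of 5-carboxypentyl on a sulfur. Among the measured compounds shown here, the one step that bears on the acid chain, a 1.5-fold higher number from compound 1 to compound 3 (0.16 log units; within the scatter), altered chain length without a shift beyond the scatter. For the measured compounds named here, no measured pair covers the branched, shortened chain of compound 4, so the step from compound 2 to compound 4 is expected to be a 1.1-fold lower number from compound 2 to compound 4 (0.02 log units; within the scatter), with wide uncertainty. Compound 4 is estimated at 4500 nM, between 1500 nM and 14000 nM.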

Compound 4, half-maximal inhibitory concentration: 5210 nM
Compound 4: middle estimate off by 1.2-fold (0.06 log units), on the low side, and the stated range covers the measured number.
By their numbers in this assay, from the lowest: compounds 1, 3, 2 and 4 (each within the scatter of the next, the first and the last beyond it).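

On a sulfur whose other neighbour is an aromatic carbon, 1-carboxy-1-methylethyl in place of 5-carboxypentyl gives a 1.1-fold higher number from compound 2 to compound 4 (0.04 log units; within the scatter) in this assay. Branching at the carbon on the sulfur, with 6 heavy atoms in the group against 8, thus leaves the two groups unseparated, whereas the earlier step covered straight chains only. No available evidence bears on this result.

Open, going by these compounds, is how a chain ending in a primary amide instead of the carboxylic acid reads at this sulfur. Also open, on these data alone, is whether 1-carboxy-1-methylethyl reads alike on the core of compound 1.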